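This account rests on a few compounds, and the source may have more. Where it says the series, first, only, none or still open, it means among the compounds named here.

The measured compounds are compound 1 `CC(=O)OC(C)n1cnc2c(Cl)nc(N)nc21`, compound 2 `CC(=O)OC(C)n1cnc2c(Cl)nc(F)nc21` and compound 3 `CC(=O)OCCOn1cnc2c(S)nc(N)nc21`. In a functional assay on SW-620 cells (Homo sapiens) for inhibition (a lower number here means a stronger inhibitor, a higher number a weaker inhibitor), compound 1 reaches only > 500000 nM, which is a limit of the assay and not a number. Compound 2 gives 8900 nM in this assay, and compound 3 gives 4200 nM. There is an at least 56-fold lower number from compound 1 to compound 2 (1.74 log units; beyond the scatter), the change being (fluoro in place of amino on an aromatic carbon). Compound 3 carries a different core from compound 1, and that difference is not broken down here. Compound 4 `CC(=O)OCCOn1cnc2c(S)nc(F)nc21` is not yet measured; it differs from compound 3 by fluoro in place of amino on an aromatic carbon, the same kind of change as from compound 1 to compound 2, here meta to a sulfanyl group rather than meta to a chloro group. Resting on an at least 56-fold lower number from compound 1 to compound 2 (1.74 log units; beyond the scatter), compound 4 is expected to show a 28-fold lower number from compound 3 to compound 4 (1.45 log units; beyond the scatter) in this assay. Compound 4 is accordingly estimated at 150 nM, most likely between 20 nM and 1500 nM.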

Compound 4, half-maximal inhibitory concentration: > 500000 nM
Compound 4 gave a limit, no number; the forecaster's own chance of this, stated with the estimate: 0%; middle value at least 3300-fold (3.52 log units) from the limit.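

In this assay, fluoro in place of amino on an aromatic carbon gives an at least 110-fold higher number from compound 3 to compound 4 (2.07 log units; beyond the scatter), so the change does not carry over from the core of compound 1 to the core of compound 3, and its direction reverses: the same change on two cores in this assay, an at least 56-fold lower number (1.74 log units; beyond the scatter) from compound 1 to compound 2 and an at least 110-fold higher number (2.07 log units; beyond the scatter) from compound 3 to compound 4, at least 6600-fold (3.82 log units) apart, beyond the scatter of two such steps. Compound 1 and compound 4 each stand at a limit of the assay and not at a number, so neither step has a known size, only a direction: the limit of > 500000 nM in this assay, at which 2 of the 4 values shown sit. The sulfanyl group in place of chloro and a different chain both separate the two cores, and these compounds cannot tell which of the two differences matters.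

From the compounds shown here alone, it remains open how a hydroxyl or methyl group in the same place would behave on either core. Going by these compounds, it also remains open whether a methylsulfanyl group in place of sulfanyl would change the outcome of the step.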